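Methoxy groups and lung stability of compound 4

The source may hold more compounds than are shown below. What is called first, only, known or untested is meant among the compounds shown, and "the series" means these compounds.

Measured in an ADME assay on S9 fraction from lung (Homo sapiens) for metabolic stability, read by LC-MS, using NADPH, with a stated time of 60 min, tested at 1 uM; on this read-out lower numbers stand for a less stable compound and higher numbers for a more stable compound:
compound 1 `CNC(=O)c1cc(S(=O)(=O)N2CCS[C@H]2C(=O)O[C@@H](Cc2c(Cl)c[n+]([O-])cc2Cl)c2ccc(OC(F)F)c(OCC3CC3)c2)cn1C`: 63.5%
compound 2 `COc1ccc(S(=O)(=O)N2CCCC[C@H]2C(=O)O[C@@H](Cc2c(Cl)c[n+]([O-])cc2Cl)c2ccc(OC(F)F)c(OCC3CC3)c2)cc1C(=O)N(C)C`: 59.7%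
compound 3 `CN(C)C(=O)c1cccc(S(=O)(=O)N2CCCC[C@H]2C(=O)O[C@@H](Cc2c(Cl)c[n+]([O-])cc2Cl)c2ccc(OC(F)F)c(OCC3CC3)c2)c1`: 72.5%

The value of compound 1 lies within the usual scatter of those of both compound 2 and compound 3. Compound 4 `COc1ccc(S(=O)(=O)N2CCS[C@H]2C(=O)O[C@@H](Cc2c(Cl)c[n+]([O-])cc2Cl)c2ccc(OC(F)F)c(OCC3CC3)c2)cc1OC` remains unmeasured. It differs from compound 1 as follows: a group of 10 heavy atoms (8 carbon, 2 oxygen; one six-membered aromatic ring of carbon only) in place of a group of 10 heavy atoms (7 carbon, 2 nitrogen, 1 oxygen; one five-membered aromatic ring with 1 hetero atom), on a sulfonyl sulfur. Within the data shown here, no measured step makes this exchange. The nearest, a number 12.8 percentage points higher from compound 2 to compound 3 (beyond the scatter), puts hydrogen in place of methoxy on an aromatic carbon, and it lies beyond the scatter. It hints at a lower number for compound 4, which carries 3,4-dimethoxyphenyl, though only weakly. The expected change is a number 5.5 percentage points lower from compound 1 to compound 4 (within the scatter), which would stay within the scatter. Compound 4 is estimated at 58%, with an expected range of 42% to 72%.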

Compound 4, percent of the compound remaining: 50.7%
Beside the measured number, compound 4's estimate is 7.3 percentage points above it, within the range that was stated.
By their numbers in this assay, from the lowest: compounds 4, 2, 1 and 3 (each within the scatter of the next, the first and the last beyond it).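

On the sulfonyl sulfur, 3,4-dimethoxyphenyl in place of the five-membered aromatic ring of compound 1 gives a number 12.8 percentage points lower from compound 1 to compound 4 (beyond the scatter) in this assay. Among the compounds shown, this is the only step that exchanges the whole group at this place, and it shows that the exchange alone, with the rest of the compound unchanged, can move the number beyond the scatter. Nothing available here accounts for this step.

The compounds shown leave open whether both methoxy groups of compound 4 matter for this step or only one. Going by these compounds, it also remains open how an unsubstituted phenyl or a phenyl carrying an amine would compare on the sulfonyl sulfur.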